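The source may hold more compounds than are shown below. What is called first, only, known or untested is meant among the compounds shown, and "the series" means these compounds.

Compound 1 `COc1cc2cc(Oc3ccc(NC(=O)Nc4cccc(C(F)(F)F)c4)cc3)c(C)nc2cc1OC` gives 4490 nM. Compound 2 `COc1cc2cc(Oc3ccc(NC(=O)Nc4ccc(Cl)c(C(F)(F)F)c4)cc3)c(C)nc2cc1OC` gives 2650 nM.

In a functional assay on NCI-H522 cells (Homo sapiens) for inhibition, read by sulforhodamine B assay, with a stated time of 48 h (on this read-out higher numbers stand for weaker inhibition of growth and lower numbers for stronger inhibition of growth), compound 2 gives the lower of the two numbers, though its gap to compound 1 lies within the scatter. Compound 3 `COc1cc2cc(Oc3ccc(NC(=O)Nc4ccc(Cl)c(Cl)c4)cc3)c(C)nc2cc1OC` differs from compound 2 by chloro in place of trifluoromethyl on an aromatic carbon. Within the data shown here, the only measured step, a 1.7-fold lower number from compound 1 to compound 2 (0.23 log units; within the scatter), concerns a different position and is itself within the scatter; no measured step swaps a trifluoromethyl for a chloro. The step from compound 2 to compound 3 is therefore expected to be small, about a 1.3-fold higher number from compound 2 to compound 3 (0.12 log units; within the scatter). Compound 3 is estimated at 3500 nM, with a range from 1400 nM to 9000 nM.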

Compound 3, concentration for total growth inhibition: 8430 nM
Compound 3: the middle estimate sits 2.4-fold (0.38 log units) below what was measured; the range from low to high includes it.
By their numbers in this assay, from the lowest: compounds 2, 1 and 3 (each within the scatter of the next, the first and the last beyond it).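

In this assay, among these compounds, this position gives the first step beyond the scatter (a 3.2-fold higher number from compound 2 to compound 3 (0.50 log units; beyond the scatter)), so with the 4-chloro group in place, chloro and trifluoromethyl are not interchangeable here. The broader change (a 1.9-fold higher number from compound 1 to compound 3 (0.27 log units; within the scatter)) stays within the scatter, so 3,4-dichlorophenyl and 3-(trifluoromethyl)phenyl cannot be told apart in this assay. No measurement shown explains the step between compound 2 and compound 3. Still open, going by these compounds, is where a methyl, a methoxy or a nitrile at this position would fall relative to compound 2 and compound 3.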